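Changing the Ester Arm in a Buffer Stability Test

The source may hold more compounds than are shown below. What is called first, only, known or untested is meant among the compounds shown, and "the series" means these compounds.

Three compounds built on one shared core were tested in a physicochemical assay for metabolic stability, read by LC-MS, in phosphate buffer, with a stated time of 3 h, at pH 7.4, tested at 50 uM; a higher number here means that more of the compound is left, a lower number that less of the compound is left. Compound 1, `C[C@@H](O)[C@H]1C(=O)N2C3=C(S[C@@H]4CN[C@@H](C4)C(=O)Nc4cccc(c4)C(=O)OCOCOC3=O)[C@H](C)[C@H]12`, gives > 95%, which is a limit of the assay rather than a number. Compound 2, `CC(C)C(=O)OCOC(=O)C1=C(S[C@@H]2CN[C@H](C(=O)Nc3cccc(C(=O)O)c3)C2)[C@H](C)[C@@H]2[C@@H]([C@@H](C)O)C(=O)N12`, likewise reaches > 95%, again a limit and not a number. Compound 3, `CC(C)OC(=O)c1cccc(NC(=O)[C@@H]2C[C@H](SC3=C(C(=O)O)N4C(=O)[C@H]([C@@H](C)O)[C@H]4[C@H]3C)CN2)c1`, gives > 95%, also a limit. Compound 2 therefore stands exactly where the other two measured compounds stand: the limit of > 95% in this assay, at which 3 of the 3 values shown sit. With every result sitting at that limit, the numbers allow no ranking and show no spread among the three.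

Compound 4, `C[C@@H](O)[C@H]1C(=O)N2C(C(=O)OCOC(=O)OC(C)(C)C)=C(S[C@@H]3CN[C@H](C(=O)Nc4cccc(C(=O)O)c4)C3)[C@H](C)[C@H]12`, has not yet been measured. It differs from compound 2 in one place: tert-butoxy in place of isopropyl on a carbonyl carbon. No change between two measured compounds is available to set the size of such a step, so the expectation rests on the three limits alone. The step is expected to be a step that the limit leaves unreadable from compound 2 to compound 4, that is, nothing beyond the usual scatter. For compound 4 the estimated value in this assay is 96%, with a range from 90% to 100%, and most likely the test will once more report only the limit rather than a number.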

Compound 4, percent of the compound remaining: > 95%
Compound 4 ended at the assay's limit; the forecaster's own chance of this, stated with the estimate: 80%; the middle value lies beyond the limit too.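

No step can be read from compound 2 to compound 4 in this assay; both results are limits of the assay, not numbers. The same holds across the series: the limit of > 95% in this assay, at which 4 of the 4 values shown sit.

The compounds shown leave open whether tert-butoxy and isopropyl on this carbonyl carbon differ at all in this assay, since a difference could only appear in results below the limit.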